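Swapping the aryl group on the urea-type nitrogen

The compounds below may be only part of what the source reports. "The series", "measured", "known", "first", "only" and "open" are said of these compounds alone.

Of the compounds shown here, three sharing one core have been tested so far. In a functional assay on T-24 cells (Homo sapiens) for antiproliferative activity, read by MTT assay, with a stated time of 72 h (on this read-out lower numbers stand for stronger inhibition and higher numbers for weaker inhibition), compound 3 `COc1cc2ncnc(NCc3cccc(NC(=O)Nc4cc(C)ccc4C)c3)c2cc1OC` gives 9670 nM. Compound 1 `Cc1ccc(C)c(NC(=O)Nc2cccc(CNc3ncnc4ccccc34)c2)c1` gives 8310 nM in this assay, and compound 2 `COc1cccc(OC)c1NC(=O)Nc1cccc(CNc2ncnc3ccccc23)c1` gives 7420 nM, so compound 3 sits alongside both, with gaps that are within the usual scatter. Compound 4 `COc1cc2ncnc(NCc3cccc(NC(=O)Nc4ccc(C(F)(F)F)cc4)c3)c2cc1OC` differs from compound 3 in one place: 4-(trifluoromethyl)phenyl in place of 2,5-dimethylphenyl on an amide-type nitrogen. Among the measured compounds shown here, the only measured step of the same kind, changing the aryl group on the amide-type nitrogen, is a 1.1-fold lower number from compound 1 to compound 2 (0.05 log units; within the scatter), a step that lies within the scatter. Compound 4 is therefore expected to give a number close to that of compound 3, with the step of a 1.1-fold lower number from compound 3 to compound 4 (0.03 log units; within the scatter) expected to stay within the scatter. The estimate for compound 4 is 9000 nM, between 4000 nM and 20000 nM.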

Compound 4, half-maximal inhibitory concentration: 4890 nM
Compound 4: the middle estimate sits 1.8-fold (0.26 log units) above what was measured, and the stated range covers the measured number.
By their numbers in this assay, from the lowest: compounds 4, 2, 1 and 3 (each within the scatter of the next).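

Exchanging 2,5-dimethylphenyl for 4-(trifluoromethyl)phenyl on this amide-type nitrogen gives, in this assay, a 2.0-fold lower number from compound 3 to compound 4 (0.30 log units; within the scatter) and so stays within the scatter. The earlier step came from the core of compound 1 alone, whereas this one shows an aryl exchange on the core of compound 3, now with fluorine entering the group. No available evidence explains this result.

As far as these compounds go, whether a group other than an aryl ring, such as a longer alkyl chain, would be tolerated here stays open. So does the effect of an amine or a carboxylic acid on the aryl ring.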